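Series notes: replacing the methoxyphenyl arm with hexyl

A few compounds are considered here, and "the series" means these few. Any claim that something is new, unique, unknown or untested is made for them only; others in the source may bear on it.

In a functional assay on SMMC-7721 cells (Homo sapiens) for cytotoxicity, read by MTT assay, with a stated time of 72 h (on this read-out higher numbers stand for weaker inhibition and lower numbers for stronger inhibition), the measured compounds give:
compound 1 `[O-][n+]1nc(NCOCc2ccc(C(F)(F)F)cc2)[n+]([O-])c2ccccc21`: 780 nM
compound 2 `COc1ccc(COCNc2n[n+]([O-])c3ccccc3[n+]2[O-])cc1`: 1150 nM
compound 3 `CC(OCNc1n[n+]([O-])c2ccccc2[n+]1[O-])c1ccccc1`: 2470 nM

Compound 2 stands second highest of the three numbers. Its nearest neighbour is compound 1, with a 1.5-fold higher number from compound 1 to compound 2 (0.17 log units; within the scatter), a step that does not leave the scatter. Among the measured compounds shown here, its furthest is compound 3, whose number lies beyond the scatter from that of compound 2; compound 3 also differs from compound 2 in more than one place, so no single step is drawn between them.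

Compound 4 `CCCCCCCOCNc1n[n+]([O-])c2ccccc2[n+]1[O-]` is the unmeasured member. The change from compound 2 is hexyl in place of 4-methoxyphenyl on a saturated chain carbon bound to an oxygen on a saturated carbon. For the measured compounds named here, the only step measured, from compound 1 to compound 2, concerns a substituent on the aromatic ring that is now removed entirely, so it speaks to this change only weakly. Going by the values given here, no measured pair shows the aromatic ring replaced by a chain. The expectation for this assay is therefore a small rise in the number, possibly none beyond the scatter, with a 1.6-fold higher number from compound 2 to compound 4 (0.19 log units; within the scatter) as the estimated step. Compound 4 is estimated at 1800 nM, between 700 nM and 4500 nM.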

Compound 4, half-maximal inhibitory concentration: 3090 nM
Compound 4: the middle estimate sits 1.7-fold (0.23 log units) below what was measured, and the stated range covers the measured number.
By their numbers in this assay, from the lowest: compounds 1 and 2 (each within the scatter of the next); then compounds 3 and 4 (each within the scatter of the next).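

In this assay the saturated chain carbon bound to an oxygen accepts hexyl in place of 4-methoxyphenyl, with a 2.7-fold higher number from compound 2 to compound 4 (0.43 log units; beyond the scatter) as the price, so compound 4 keeps a measurable number without any ring on the arm. The earlier step of a 1.5-fold higher number from compound 1 to compound 2 (0.17 log units; within the scatter) kept the aromatic ring and stayed within the scatter, which makes this the first single-place change shown to move the number beyond it. No measured property is at hand to account for this rise.

On these data alone, whether the rise follows from losing the ring or from the shape of the chain stays open, and a cyclohexyl group at the same place would help to separate the two. Also open, as far as these compounds go, is how a longer chain, or a chain ending in an amine or a carboxylic acid, would read in this assay.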